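The source may hold more compounds than are shown below. What is called first, only, known or untested is meant among the compounds shown, and "the series" means these compounds.

Measured so far:
- compound 1, `COc1ccc2oc(CSC(=S)N3CCOCC3)cc(=O)c2c1`, in a functional assay on HEp-2 cells (Homo sapiens) for antiproliferative activity, read by MTT assay, with a stated time of 72 h (on this read-out lower numbers stand for stronger inhibition and higher numbers for weaker inhibition), gives 3000 nM
- compound 2, `O=c1c(Cl)c(CSC(=S)N2CCOCC2)oc2ccccc12`, in this assay gives 9000 nM
- compound 3, `CC(C)N(C(=S)SCc1cc(=O)c2ccccc2o1)C(C)C`, in this assay gives 13600 nM

Compound 3 has the largest number of the three. Set against compound 2, the gap is within the usual scatter of repeated measurements, so the two cannot be told apart; set against compound 1, the gap is beyond the scatter, and compound 1 is the one that inhibits growth at a clearly lower concentration.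

Compound 4, `O=c1cc(CSC(=S)N2CCOCC2)oc2ccccc12`, has not yet been measured in this assay. It differs from compound 3 in one place: morpholin-4-yl in place of diisopropylamino on a thiocarbonyl carbon. Among the compounds with values here, no step between measured compounds isolates this change, so the size of its effect is unknown. Compounds 1 and 2 both carry the morpholin-4-yl group and both give numbers below that of compound 3, which is the only hint available. The expected step from compound 3 to compound 4 is a 2.3-fold lower number from compound 3 to compound 4 (0.36 log units; beyond the scatter), a modest move toward a lower number. Compound 4 is therefore estimated at 6000 nM, with a range from 2500 nM to 14000 nM.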

Compound 4, half-maximal inhibitory concentration: > 25000 nM
Compound 4: only a limit was reported (the forecaster's own chance of this, stated with the estimate: 5%); middle value at least 4.1-fold (0.61 log units) from the limit.
By their numbers in this assay, from the lowest: compound 1; then compounds 2 and 3 (each within the scatter of the next). At a limit, above all of these: compound 4.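

In this assay compound 4 gives only a limit, not a number: the limit of > 25000 nM in this assay, at which 1 of the 4 values shown sits. With hydrogen in place of chloro on an aromatic carbon the change is an at least 2.7-fold higher number from compound 2 to compound 4 (0.44 log units; beyond the scatter), and with hydrogen in place of methoxy on an aromatic carbon it is an at least 8.3-fold higher number from compound 1 to compound 4 (0.92 log units; beyond the scatter), so either group goes with clearly stronger inhibition than hydrogen when morpholin-4-yl is present. Morpholin-4-yl in place of diisopropylamino on a thiocarbonyl carbon gives an at least 1.8-fold higher number from compound 3 to compound 4 (0.26 log units; that floor lies within the scatter), so morpholin-4-yl alone shows no sign of a lower number than diisopropylamino.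

As far as these compounds go, how far compound 4 lies past its limit stays open, and with it the true size of all three steps. Also open, from the compounds shown here alone, is whether a fluoro or methyl group on an aromatic carbon, or a piperidin-1-yl group on the thiocarbonyl carbon, would follow the same course.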